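Cytotoxicity notes: sulfanyl group replacing imidazolyl on compound 2

The compounds below may be only part of what the source reports. "The series", "measured", "known", "first", "only" and "open" are said of these compounds alone.

Compound 1 `Cc1cc(N2CCCC2)c2ncc(CSCCc3ccccc3)n2c1`: > 100 ug/mL (a limit)
Compound 2 `Cc1cc(-n2ccnc2)c2ncc(CSCCc3ccccc3)n2c1`: 10 ug/mL
Compound 3 `Cc1cc(Sc2ccc(Cl)cc2)c2ncc(CSCCc3ccccc3)n2c1`: not yet measured

For the measured compounds named here, in an ADME assay on HEL cells (Homo sapiens) for cytotoxicity, with a stated time of 3 days (on this read-out lower numbers stand for higher toxicity in this test and higher numbers for lower toxicity in this test), compound 2 gives 10 ug/mL, the only actual number so far. The value of compound 1 is a limit, > 100 ug/mL.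

Compound 3 differs from compound 2 as follows: (4-chlorophenyl)sulfanyl in place of 1H-imidazol-1-yl on an aromatic carbon. Going by the values given here, the one measured step at this place is an at least 10-fold lower number from compound 1 to compound 2 (1.00 log units; beyond the scatter), and it is the step that brought 1H-imidazol-1-yl in. Among the compounds with values here, compound 3 loses that group, but no measured step covers (4-chlorophenyl)sulfanyl, so the direction remains uncertain. On the evidence of an at least 10-fold lower number from compound 1 to compound 2 (1.00 log units; beyond the scatter), a moderate move to a higher number is expected, and the estimated step is a 4.0-fold higher number from compound 2 to compound 3 (0.60 log units; beyond the scatter). The estimated value for compound 3 is 40 ug/mL, with an expected range of 10 ug/mL to 100 ug/mL.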

Compound 3, half-maximal cytotoxic concentration: 100 ug/mL
Estimate against measurement, compound 3: 2.5-fold (0.40 log units) below; low and high end bracket the measured number.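

In this assay, an aromatic group at this carbon, ortho to a fused ring, does not by itself go with a low number: (4-chlorophenyl)sulfanyl in place of 1H-imidazol-1-yl gives a 10-fold higher number from compound 2 to compound 3 (1.00 log units; beyond the scatter). The larger group, with 8 heavy atoms against 5, therefore sits on the higher side, and of the three compounds, compound 2 alone has the low number. (4-chlorophenyl)sulfanyl in place of pyrrolidin-1-yl gives a number no higher from compound 1 to compound 3 (the limit leaves the size open), a step whose size cannot be read. The value of compound 1 is a limit: the limit of > 100 ug/mL in this assay, at which 1 of the 3 values shown sits.

The compounds shown leave open whether the sulfur link, the chlorine or the carbon-only ring accounts for the step to compound 3. A plain phenylsulfanyl group or a 4-chloroanilino group at this carbon would separate these parts.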